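Swapping nitro for amino on a triazole-linked trimethoxyphenyl scaffold

The source may hold more compounds than are shown below. What is called first, only, known or untested is meant among the compounds shown, and "the series" means these compounds.

Measured so far in a functional assay on K562 cells (Homo sapiens) for cytotoxicity, read by MTT assay, with a stated time of 5 days; a higher number here means a weaker inhibitor, a lower number a stronger inhibitor:
compound 1, `COc1ccc(Cn2nncc2-c2cc(OC)c(OC)c(OC)c2)cc1[N+](=O)[O-]`: > 10000 nM
compound 2, `COc1ccc(Cn2nncc2-c2cc(OC)c(OC)c(OC)c2)cc1N`: 730 nM
compound 3, `COc1ccc(-c2cn(-c3cc(OC)c(OC)c(OC)c3)nn2)cc1[N+](=O)[O-]`: > 10000 nM

Compound 1 reaches only a limit of this assay, not a number: in this assay compound 1 gives > 10000 nM. Compound 2 differs from compound 1 in one place, (amino in place of nitro on an aromatic carbon), and in this assay compound 2 gives 730 nM. The step is an at least 13-fold lower number from compound 1 to compound 2 (1.13 log units; beyond the scatter), and its true size cannot be fixed because of the limit of > 10000 nM in this assay, at which 2 of the 3 values shown sit.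

Compound 3 is built on a different core; the difference between the two cores is not broken down here. Compound 3 also reaches only a limit of this assay, not a number: in this assay compound 3 gives > 10000 nM.

Compound 4, `COc1ccc(-c2cn(-c3cc(OC)c(OC)c(OC)c3)nn2)cc1N`, has not yet been measured. It differs from compound 3 by amino in place of nitro on an aromatic carbon. The place of the change is described in the same words for both pairs, so this is the same change as that from compound 1 to compound 2. Since that change gave an at least 13-fold lower number from compound 1 to compound 2 (1.13 log units; beyond the scatter), a step of similar direction is expected here, an at least 5.0-fold lower number from compound 3 to compound 4 (0.69 log units; beyond the scatter), though the different core of compound 3 means the size is uncertain. Compound 4 is therefore expected to give about 2000 nM in this assay, somewhere between 400 nM and 10000 nM.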

Compound 4, half-maximal inhibitory concentration: 1300 nM
For compound 4 the middle estimate is 1.5-fold (0.19 log units) above the measured one; low and high end bracket the measured number.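

Amino in place of nitro on an aromatic carbon gives an at least 7.6-fold lower number from compound 3 to compound 4 (0.88 log units; beyond the scatter) in this assay, so the change points the same way on both cores shown. This is a result from two matched pairs only, and setting their steps side by side does not settle whether the core alters the size of the gain: the same change on two cores in this assay, an at least 13-fold lower number (1.13 log units; beyond the scatter) from compound 1 to compound 2 and an at least 7.6-fold lower number (0.88 log units; beyond the scatter) from compound 3 to compound 4; the limit leaves it open whether they differ. Going by these compounds, each step is only a minimum, and its true size stays unknown, because both nitro compounds give a limit rather than a number: the limit of > 10000 nM in this assay, at which 2 of the 4 values shown sit.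

The compounds shown leave open whether amino itself matters or whether other groups at the same place, such as a hydroxyl, a methylamino group or an acetamide, would also give a lower number than nitro. They also leave open whether the same swap would point the same way on a third core, as two cores are too few to establish a general rule for this series.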